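The source may report more compounds than this note shows. Statements on the series, on what has been measured and on what is new or still open speak of the compounds shown alone.

Measured compounds:
- compound 1 `O=C(Nc1nc2ccc(F)cc2s1)c1cn(-c2ccccc2)nc1-c1ccc(F)cc1`: 5260 nM
- compound 2 `O=C(Nc1nc2ccccc2s1)c1cn(-c2ccccc2)nc1-c1ccc(Cl)cc1`: 7750 nM

In a functional assay on PC-3 cells (Homo sapiens) for cytotoxicity, read by MTT assay, with a stated time of 72 h (a lower number here means a stronger inhibitor, a higher number a weaker inhibitor), compound 1 gives 5260 nM. In this assay compound 2 gives 7750 nM. These two numbers sit within the usual scatter of each other, so no order can be read between compound 2 and compound 1. Compound 3 `O=C(Nc1nc2ccc(F)cc2s1)c1cn(-c2ccccc2)nc1-c1ccc(Cl)cc1` differs from compound 2 by fluoro in place of hydrogen on an aromatic carbon. Among the measured compounds shown here, no measured pair shows this change on its own, so no step beyond the scatter is expected in this assay in either direction. For compound 3 the expected value is 6500 nM, within 2500 nM to 16000 nM, an estimated step of a 1.2-fold lower number from compound 2 to compound 3 (0.08 log units; within the scatter).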

Compound 3, half-maximal inhibitory concentration: 5790 nM
The estimate for compound 3 lay 1.1-fold (0.05 log units) above the measured number; measured number inside the range.
By their numbers in this assay, from the lowest: compounds 1, 3 and 2 (each within the scatter of the next).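

Replacing 1,3-benzothiazol-2-yl with 6-fluoro-1,3-benzothiazol-2-yl gives a 1.3-fold lower number from compound 2 to compound 3 (0.13 log units; within the scatter) in this assay, so the first direct test of this change finds no effect that stands out from the scatter. Chloro in place of fluoro on an aromatic carbon gives a 1.1-fold higher number from compound 1 to compound 3 (0.04 log units; within the scatter) and is equally indistinguishable from the scatter. No outside evidence bears on these results. Still open, from the compounds shown here alone, is whether a larger change at the fluoro position, such as an amine, a carboxylic acid or a longer chain, would move the number beyond the scatter.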